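Trimming the Sulfonamide Nitrogen of Compound 1

The source may report more compounds than this note shows. Statements on the series, on what has been measured and on what is new or still open speak of the compounds shown alone.

Compound 1 `Cc1oncc1NS(=O)(=O)c1ccc(F)c2ncc(I)cc12` is measured in an assay for inhibition of methylcytosine dioxygenase TET2 (Homo sapiens), read by mass spectrometry, with stated times of 30 min and 1 h (a higher number here means a weaker inhibitor, a lower number a stronger inhibitor), where compound 1 gives 2100 nM. Among the numbers shown, compound 2 `O=S(=O)(O)c1ccc(F)c2ncc(I)cc12` gives 2300 nM, and the step of a 1.1-fold higher number from compound 1 to compound 2 (0.04 log units; within the scatter) stays within the scatter. Compound 3 `COS(=O)(=O)c1ccc(F)c2ncc(I)cc12` reaches only the limit > 200000 nM in this assay. The step of an at least 86-fold higher number from compound 2 to compound 3 (1.93 log units; beyond the scatter) is a large loss. Compound 4 `NS(=O)(=O)c1ccc(F)c2ncc(I)cc12` differs from compound 1 by hydrogen in place of 5-methyl-1,2-oxazol-4-yl on a sulfonamide nitrogen. The step from compound 1 to compound 2 bears most on this change, as it also removes the 5-methyl-1,2-oxazol-4-yl group and leaves a hydrogen-bearing atom on the sulfonyl sulfur; that step stayed within the scatter. Only compound 3, with methyl in place of hydrogen, lost activity. The step of a 1.4-fold higher number from compound 1 to compound 4 (0.15 log units; within the scatter) is therefore expected to be small. Compound 4 is estimated at 3000 nM, within 1000 nM to 10000 nM.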

Compound 4, half-maximal inhibitory concentration: 86600 nM
For compound 4 the middle estimate is 29-fold (1.46 log units) below the measured one; the whole stated range lies below it.
By their numbers in this assay, from the lowest: compounds 1 and 2 (each within the scatter of the next); then compound 4. At a limit, above all of these: compound 3.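

The step of a 41-fold higher number from compound 1 to compound 4 (1.62 log units; beyond the scatter) shows that the 5-methyl-1,2-oxazol-4-yl group on this sulfonamide nitrogen cannot simply be dropped, even though the hydroxy of compound 2 matches compound 1 within the scatter. On the sulfonyl sulfur, amino does not stand in for hydroxy, as the step of a 38-fold higher number from compound 2 to compound 4 (1.58 log units; beyond the scatter) shows. Amino does better than methoxy in the step of an at least 2.3-fold lower number from compound 3 to compound 4 (0.36 log units; beyond the scatter), but compound 3 sits at a limit of the assay, so this step has no fixed size: the limit of > 200000 nM in this assay, at which 1 of the 4 values shown sits.

Still open, from the compounds shown here alone, is how much of the 5-methyl-1,2-oxazol-4-yl group the nitrogen needs. A single methyl, a longer chain or a phenyl ring there could each behave differently.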